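Trimethoxyphenyl for 3-nitrophenyl in the compound 1 series

This account rests on a few compounds, and the source may have more. Where it says the series, first, only, none or still open, it means among the compounds named here.

In a functional assay on QGY-7703 cells (Homo sapiens) for cytotoxicity, read by MTT assay, with a stated time of 24 h (a lower number here means a stronger inhibitor, a higher number a weaker inhibitor), compound 1 `O=C1/C(=C/c2cccc([N+](=O)[O-])c2)CN(S(=O)(=O)c2ccc(F)cc2)C/C1=C\c1cccc([N+](=O)[O-])c1` gives 11900 nM and compound 2 `CC(=O)Nc1ccc(S(=O)(=O)N2C/C(=C\c3cccc([N+](=O)[O-])c3)C(=O)/C(=C/c3cccc([N+](=O)[O-])c3)C2)cc1` gives 6760 nM within the scatter of it, so compound 1 stands level with compound 2. Compound 3 `COc1cc(/C=C2\CN(S(=O)(=O)c3ccc(F)cc3)C/C(=C\c3cccc([N+](=O)[O-])c3)C2=O)cc(OC)c1OC` differs from compound 1 by 3,4,5-trimethoxyphenyl in place of 3-nitrophenyl on a double-bonded chain carbon bound to a double-bonded ring carbon with 3,4,5-trimethoxyphenyl in place of 3-nitrophenyl on a double-bonded chain carbon bound to a double-bonded ring carbon. For the measured compounds named here, the only measured step is a 1.8-fold lower number from compound 1 to compound 2 (0.25 log units; within the scatter) at another place, which gives weak guidance here. No shift beyond the scatter is expected in either direction, and the estimated step is a 1.2-fold lower number from compound 1 to compound 3 (0.08 log units; within the scatter) in this assay terms. For compound 3 the estimated value is 10000 nM with 3500 nM to 30000 nM as its expected range.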

Compound 3, half-maximal inhibitory concentration: 3270 nM
Compound 3: the middle estimate sits 3.1-fold (0.49 log units) above what was measured; the measured number lies below the stated range.
By their numbers in this assay, from the lowest: compound 3; then compounds 2 and 1 (each within the scatter of the next).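

In this assay, 3,4,5-trimethoxyphenyl in place of 3-nitrophenyl on a double-bonded chain carbon bound to a double-bonded ring carbon gives a 3.6-fold lower number from compound 1 to compound 3 (0.56 log units; beyond the scatter). This place therefore moves the number beyond the scatter, which the acetamido for fluoro change elsewhere on the scaffold did not do. No evidence on hand explains the step.

Going by these compounds, it remains open whether the shift follows from the entering 3,4,5-trimethoxyphenyl or the departing 3-nitrophenyl, and what a 4-methoxyphenyl or 4-dimethylaminophenyl would give here. On these data alone, the effect of also replacing the remaining 3-nitrophenyl is equally open.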